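Moving from a methoxyphenyl to a trifluoromethylphenyl group

A few compounds are considered here, and "the series" means these few. Any claim that something is new, unique, unknown or untested is made for them only; others in the source may bear on it.

Three compounds have been measured in a functional assay on BJAB cells (Homo sapiens) for antiproliferative activity, with a stated time of 4 days; a lower number here means that less compound is needed, a higher number that more compound is needed for the effect:

compound 1, `Cc1nn(-c2nc(-c3ccc(Cl)c(Cl)c3)c(SC(C)C)s2)c(C(=O)O)c1-c1cccc(C(F)(F)F)c1`, gives 22000 nM
compound 2, `COc1cc(C#N)cc(-c2c(C)nn(-c3nc(-c4ccc(Cl)c(Cl)c4)c(SC(C)C)s3)c2C(=O)O)c1`, gives 5200 nM
compound 3, `COc1cccc(-c2c(C)nn(-c3nc(-c4ccc(Cl)c(Cl)c4)c(SC(C)C)s3)c2C(=O)O)c1`, gives 14000 nM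

Compound 3 sits second highest of the three numbers. Its nearest neighbour is compound 1, with a 1.6-fold lower number from compound 1 to compound 3 (0.20 log units; within the scatter), a gap that stays within the scatter. Compound 2 is furthest away, with a 2.7-fold higher number from compound 2 to compound 3 (0.43 log units; beyond the scatter), a modest gap beyond the scatter.

Compound 4, `Cc1nn(-c2nc(-c3ccc(Cl)c(Cl)c3)c(SC(C)C)s2)c(C(=O)O)c1-c1ccc(C(F)(F)F)cc1`, has not been measured. Compared with compound 3 the change is 4-(trifluoromethyl)phenyl in place of 3-methoxyphenyl on an aromatic carbon.

Going by the values given here, only one measured step speaks to this change: a 1.6-fold lower number from compound 1 to compound 3 (0.20 log units; within the scatter), which exchanges methoxy for trifluoromethyl on the same aromatic carbon and stays within the scatter. The steps of a 4.2-fold lower number from compound 1 to compound 2 (0.63 log units; beyond the scatter) and a 2.7-fold higher number from compound 2 to compound 3 (0.43 log units; beyond the scatter) concern a cyano group and do not bear on it. Among the compounds with values here, no measured pair shows what moving the trifluoromethyl group to a different position on the phenyl ring does, so the expectation rests on the one step alone and carries a wide range. For compound 4 the expected step is a 1.4-fold higher number from compound 3 to compound 4 (0.15 log units; within the scatter), meaning no change beyond the scatter. Compound 4 is therefore estimated at 20000 nM, within a range of 7000 nM to 60000 nM.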

Compound 4, half-maximal effective concentration: 3500 nM
The estimate for compound 4 lay 5.7-fold (0.76 log units) above the measured number, outside the stated range (below it).
By their numbers in this assay, from the lowest: compounds 4 and 2 (each within the scatter of the next); then compounds 3 and 1 (each within the scatter of the next).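

In this assay, going by these compounds alone, the place of the trifluoromethyl group on the phenyl ring turns out to matter (a 6.3-fold lower number from compound 1 to compound 4 (0.80 log units; beyond the scatter)), something no earlier pair of compounds could show. The 4-(trifluoromethyl)phenyl group also gives a lower number than the 3-methoxyphenyl group (a 4.0-fold lower number from compound 3 to compound 4 (0.60 log units; beyond the scatter)), whereas its step from the 3-cyano-5-methoxyphenyl group stays within the scatter (a 1.5-fold lower number from compound 2 to compound 4 (0.17 log units; within the scatter)), so those two groups cannot be told apart in this assay. Nothing available explains why the position of the trifluoromethyl group makes this difference.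

As far as these compounds go, it remains open whether a different group in the same place on the phenyl ring, such as a chlorine or an amine, would give a similarly low number. From the compounds shown here alone, it is also open whether the step seen here would hold if an amide replaced the carboxy group of the shared core.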